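The compounds below may be only part of what the source reports. "The series", "measured", "known", "first", "only" and "open" are said of these compounds alone.

- Compound 1 (`CC(C)(C)C1=CC(=O)C=CC1=O`) gives (> 100000 nM), a limit of the assay.
- Compound 2 (`CNC1=CC(=O)C(C(C)(C)C)=CC1=O`) gives (63000 nM), a number.

Within the data shown here, in a functional assay on NCI-H460 cells (Homo sapiens) for cytotoxicity, read by MTT assay, with a stated time of 72 h (a higher number here means a weaker inhibitor, a lower number a stronger inhibitor), compound 2 gives (63000 nM), the only number so far. Compound 3 (`CCCCNC1=CC(=O)C(C(C)(C)C)=CC1=O`) differs from compound 2 by one change (propyl in place of hydrogen on a saturated chain carbon bound to an amine nitrogen), which takes methylamino to butylamino. Among the measured compounds shown here, the one measured step (an at least 1.5-fold lower number from compound 1 to compound 2 (0.20 log units; that floor lies within the scatter)) introduces methylamino and does not vary the chain, so it bears only loosely on this change. No step beyond the scatter is therefore expected in this assay here. The expected step is (a 1.4-fold lower number from compound 2 to compound 3 (0.15 log units; within the scatter)). For compound 3 the estimated value is (45000 nM), with an expected range from 13000 nM to 100000 nM overall.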

Compound 3, half-maximal inhibitory concentration: 36000 nM
Compound 3: middle estimate off by 1.3-fold (0.10 log units), on the high side; measured number inside the range.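

In this assay the lengthening of methylamino to butylamino gives a 1.8-fold lower number from compound 2 to compound 3 (0.24 log units; within the scatter) and so stays inside the scatter. Introducing butylamino gives an at least 2.7-fold lower number from compound 1 to compound 3 (0.44 log units; beyond the scatter) and is the first step at this place to pass beyond the scatter, which the methylamino step did not do. Compound 1 stands at a limit of the assay, so this step is only a floor: the limit of > 100000 nM in this assay, at which 1 of the 3 values shown sits.

As far as these compounds go, whether a longer chain such as octylamino would carry the number further stays open. So does what a chain ending in an amine or a carboxylic acid would give.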